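The source may hold more compounds than are shown below. What is called first, only, known or untested is meant among the compounds shown, and "the series" means these compounds.

Measured so far:
compound 1 `CC(C)(CO)S(=O)(=O)c1cccc(NC(=O)c2cccnc2N2CCC3(CC2)CC3)c1` — in an ADME assay on microsomes from liver (Mus musculus) for metabolic stability, read by LC-MS, with a stated time of 40 min, tested at 0.5 uM (on this read-out higher numbers stand for fast clearance and lower numbers for slow clearance), compound 1 gives > 399 mL.min-1.g-1, a limit of the assay.
compound 2 `O=C(Nc1cccc(S(=O)(=O)C2CCCC2)c1)c1cccnc1N1CCC(F)(F)CC1` — in this assay compound 2 gives > 399 mL.min-1.g-1, likewise a limit.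
compound 3 `CC(C)(C)NS(=O)(=O)c1cccc(NC(=O)c2ccc(NS(C)(=O)=O)cc2N2CCC3(CC2)CC3)c1` — in this assay compound 3 gives 81 mL.min-1.g-1.

Compound 2 stands at the limit of > 399 mL.min-1.g-1 in this assay, at which 2 of the 3 values shown sit, so only a bound is known for it. Compound 4 `O=C(Nc1cccc(S(=O)(=O)C2CCCC2)c1)c1cccnc1N1CCC2(CC1)CC2` differs from compound 2 in one place: a group of 8 heavy atoms (7 carbon, 1 nitrogen; one three-membered non-aromatic ring of carbon only, one six-membered non-aromatic ring with 1 hetero atom) in place of a group of 8 heavy atoms (5 carbon, 1 nitrogen, 2 fluorine; one six-membered non-aromatic ring with 1 hetero atom), on an aromatic carbon. Compound 1 carries the same entering group on its core, and its value > 399 mL.min-1.g-1 is also a limit. On that basis the step from compound 2 to compound 4 is expected to be a step that the limit leaves unreadable from compound 2 to compound 4, none beyond the scatter. Compound 4 is expected to give 450 mL.min-1.g-1 in this assay, within 200 mL.min-1.g-1 to 900 mL.min-1.g-1, and most likely reported again as a limit.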

Compound 4, intrinsic clearance in microsomes: > 399 mL.min-1.g-1
Compound 4: a limit, no number (the forecaster's own chance of this, stated with the estimate: 65%); the middle value is on the limit's open side.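

Compound 4 is reported only as a limit, as are compound 1 and compound 2, so neither step to compound 4 can be read: the limit of > 399 mL.min-1.g-1 in this assay, at which 3 of the 4 values shown sit.

On these data alone, whether either exchange changes clearance, and by how much, stays open.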